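Swapping Hydrogen for Fluorine on a Weak Cell-Growth Inhibitor

A few compounds are considered here, and "the series" means these few. Any claim that something is new, unique, unknown or untested is made for them only; others in the source may bear on it.

Measured so far:
Compound 1, `COc1ccc(/C=C2\SC(=O)N(Cc3ccc(C(=O)O)cc3)C2=O)cc1`, gives 44000 nM in a functional assay on A549 cells (Homo sapiens) for cytotoxicity, read by MTT assay, with a stated time of 24 h; a lower number here means a stronger inhibitor, a higher number a weaker inhibitor.
Compound 2, `O=C(O)c1ccc(CN2C(=O)S/C(=C\c3ccccc3)C2=O)cc1`, gives 90000 nM in this assay.

Both numbers are high, so neither compound is a strong inhibitor. Among the compounds with values here, compound 2 stands at the highest of the two numbers, and its only neighbour, compound 1, sits a modest distance lower, a gap described as a 2.0-fold higher number from compound 1 to compound 2 (0.31 log units; beyond the scatter), which arises from hydrogen in place of methoxy on an aromatic carbon.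

Compound 3, `O=C(O)c1ccc(CN2C(=O)S/C(=C\c3ccc(F)cc3)C2=O)cc1`, has not yet been measured. It differs from compound 2 by fluoro in place of hydrogen on an aromatic carbon. Within the data shown here, the one measured step that bears on this position shows that removing the methoxy group raised the number by a 2.0-fold higher number from compound 1 to compound 2 (0.31 log units; beyond the scatter); nothing measured shows what fluoro does there, so the step is weakly informed. A small change in either direction, or none beyond the scatter, is expected in this assay, with the estimated step of a 1.3-fold lower number from compound 2 to compound 3 (0.11 log units; within the scatter).

Compound 3 is therefore expected to give about 70000 nM, within a range from 35000 nM to 140000 nM.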

Compound 3, half-maximal inhibitory concentration: 36000 nM
Compound 3: middle estimate off by 1.9-fold (0.29 log units), on the high side; measured number inside the range.
By their numbers in this assay, from the lowest: compounds 3 and 1 (each within the scatter of the next); then compound 2.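

Before this result, the only measured change on this aromatic carbon, para to a large group, was the loss of a methoxy group, so nothing showed whether another group could stand in for it. In this assay, adding one fluorine atom to the phenyl ring gives a 2.5-fold lower number from compound 2 to compound 3 (0.40 log units; beyond the scatter), and changing methoxy to fluoro gives a 1.2-fold lower number from compound 1 to compound 3 (0.09 log units; within the scatter), so these two different groups cannot be told apart here, while the compound carrying only hydrogen, compound 2, has the highest number of the three. Nothing measured here explains why either group gives a lower number than hydrogen.

On these data alone, all three numbers remain high, so these steps are small moves among weak inhibitors, and it stays open whether a chloro group, a nitrile or an amine on the same carbon would fall in with methoxy and fluoro or move the number much further. As far as these compounds go, it also stays open whether a longer chain there, such as ethoxy or butoxy, would keep the number where these two groups put it.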